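Hydroxy to Nitro: Expected Cytotoxicity of Compound 4

A few compounds are considered here, and "the series" means these few. Any claim that something is new, unique, unknown or untested is made for them only; others in the source may bear on it.

Of the compounds shown here, three sharing a common core have been tested in an ADME assay on Vero cells (Chlorocebus sabaeus) for cytotoxicity; on this read-out lower numbers stand for higher toxicity in this test and higher numbers for lower toxicity in this test. Compound 1 `Oc1ccc(-c2nc3cc(C(F)(F)F)ccc3[nH]2)cc1` carries a hydroxy group on its outer ring. In this assay compound 1 gives > 100000 nM, which is a limit of the test rather than a number. Compound 3 `O=[N+]([O-])c1ccc(-c2nc3cc(C(F)(F)F)ccc3[nH]2)cc1` differs from compound 1 by nitro in place of hydroxy on an aromatic carbon. In this assay compound 3 gives 45000 nM. The resulting step is an at least 2.2-fold lower number from compound 1 to compound 3 (0.34 log units; beyond the scatter), and because compound 1 sits at the limit of > 100000 nM in this assay, at which 1 of the 3 values shown sits, the true size of that step is known only as a lower bound.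

Compound 2 `Oc1ccc(-c2nc3cc(Cl)c(Cl)cc3[nH]2)cc1` keeps the hydroxy group but has a different core; the difference between the two cores is not broken down here. In this assay compound 2 gives 18000 nM, the lower of the two plain numbers recorded so far.

Compound 4 `O=[N+]([O-])c1ccc(-c2nc3cc(Cl)c(Cl)cc3[nH]2)cc1` has not yet been tested. Among the compounds with values here, it differs from compound 2 by nitro in place of hydroxy on an aromatic carbon, the same change as the one from compound 1 to compound 3, made at the same place. The expectation for it rests on that earlier pair, where the step was an at least 2.2-fold lower number from compound 1 to compound 3 (0.34 log units; beyond the scatter). Compound 4 is therefore expected to give about 8000 nM in this assay, with a likely range from 3000 nM to 25000 nM. For compound 4 this estimate means an expected step of a 2.3-fold lower number from compound 2 to compound 4 (0.35 log units; beyond the scatter), a lowering of similar size to the measured one.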

Compound 4, half-maximal cytotoxic concentration: >= 100000 nM
Compound 4: no number, only a limit; the forecaster's own chance of this, stated with the estimate: 5%; middle value at least 12-fold (1.09 log units) away from the limit.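

On the core of compound 2, nitro in place of hydroxy on an aromatic carbon gives an at least 5.5-fold higher number from compound 2 to compound 4 (0.74 log units; beyond the scatter), so in this assay this change does not carry a fixed shift from one core to the other, and its direction even turns round: the same change on two cores in this assay, an at least 2.2-fold lower number (0.34 log units; beyond the scatter) from compound 1 to compound 3 and an at least 5.5-fold higher number (0.74 log units; beyond the scatter) from compound 2 to compound 4, at least 12-fold (1.09 log units) apart, beyond the scatter of two such steps

Compound 4 gives >= 100000 nM, which is a limit of the test and not a number, and this new step, like the earlier one, is known only as a lower bound, with its true size unknown.

The two pairs show that the outcome of this change depends on the core it is made on in this series, but they do not show which feature of the cores is responsible, and two pairs give no rule for predicting the change on any further core.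

The compounds shown leave open how other groups in that same place, such as an amine, a carboxylic acid or a nitrile, would behave on these two cores. They also leave open whether a core carrying a single chlorine would follow the core of compound 1 or the core of compound 2.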